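Working notes: ring-group swap from compound 1 to compound 4

This account rests on a few compounds, and the source may have more. Where it says the series, first, only, none or still open, it means among the compounds named here.

Measured in a functional assay on MCF7 cells (Homo sapiens) for antiproliferative activity, read by CellTiter-Glo, with a stated time of 5 days; on this read-out higher numbers stand for weaker inhibition and lower numbers for stronger inhibition:
compound 1 `CC/C(=C(/c1ccc(/C=C/C(=O)O)cc1)c1ccn2nccc2c1)c1ccccc1`: > 500 nM (a limit)
compound 2 `CC/C(=C(/c1ccc(/C=C/C(=O)O)cc1)c1ccn2nncc2c1)c1ccccc1`: > 500 nM (a limit)
compound 3 `CC/C(=C(/c1ccc(/C=C/C(=O)O)cc1)c1ccc2nncn2c1)c1ccccc1`: > 500 nM (a limit)

Compound 1 stands at > 500 nM, which is a limit and not a number. Across the three measured compounds, the picture is the limit of > 500 nM in this assay, at which 3 of the 3 values shown sit.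

Compound 4 `CC/C(=C(/c1ccc(/C=C/C(=O)O)cc1)c1ccc2nnnn2c1)c1ccccc1` is still unmeasured, and the change leading to it is a group of 9 heavy atoms (5 carbon, 4 nitrogen; one five-membered aromatic ring with 4 hetero atoms, one six-membered aromatic ring with 1 hetero atom) in place of a group of 9 heavy atoms (7 carbon, 2 nitrogen; one five-membered aromatic ring with 2 hetero atoms, one six-membered aromatic ring with 1 hetero atom), on a double-bonded chain carbon bound to an aromatic carbon and a double-bonded chain carbon. The entering group has 4 hydrogen-bond acceptors and the leaving group 2, and neither has a net charge.

The measured swaps at the same place are a step that the two limits leave unreadable from compound 1 to compound 2, a step that the two limits leave unreadable from compound 1 to compound 3 and a step that the two limits leave unreadable from compound 2 to compound 3. None of them gives a size, so no direction can be taken from them.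

The expectation therefore rests on compound 3 , whose > 500 nM is a limit. No step beyond the scatter is expected in this assay, and the expected step is a step that the limit leaves unreadable from compound 1 to compound 4. The estimate for compound 4 is 1000 nM, with an expected range of 400 nM to 5000 nM.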

Compound 4, half-maximal inhibitory concentration: > 500 nM
Compound 4: a limit, no number; the forecaster's own chance of this, stated with the estimate: 85%; the middle value lies beyond the limit too.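

Compound 4 in this assay gives > 500 nM, a limit and not a number. No step from compound 1, compound 2 or compound 3 to compound 4 can be read, and the series rests on a single limit: the limit of > 500 nM in this assay, at which 4 of the 4 values shown sit.

The compounds shown leave open how far the four lie from one another and whether any of these ring-group swaps alters antiproliferative activity.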